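A few compounds are considered here, and "the series" means these few. Any claim that something is new, unique, unknown or untested is made for them only; others in the source may bear on it.

In a functional assay on RS4-11 cells (Homo sapiens) for inhibition, read by CCK-8 assay, with a stated time of 48 h (a higher number here means a weaker inhibitor, a lower number a stronger inhibitor), compound 1 (`Cc1cc(C)cc(NC(=O)NCCNS(=O)(=O)c2ccc(-c3ccccc3Oc3ccc([N+](=O)[O-])c([N+](=O)[O-])c3)s2)c1`) gives 3600 nM. Compound 3 (`COc1ccc(NC(=S)NCCNS(=O)(=O)c2sccc2-c2ccc(C)cc2Oc2ccc(O)c(O)c2)cc1`) gives 8300 nM, the higher of the two numeric values, and its gap to compound 1 lies beyond the usual scatter. Compound 2 (`O=C(NCCNS(=O)(=O)c1ccc(-c2ccccc2OCc2cccc(O)c2)s1)Nc1cc(Cl)cc(Cl)c1`) reads > 50000 nM, which is a limit of this assay and not a number.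

Compound 4 (`Cc1ccc(-c2ccsc2S(=O)(=O)NCCNC(=O)Nc2cccc([N+](=O)[O-])c2)c(Oc2ccc(O)c(O)c2)c1`) has not yet been measured. It differs from compound 3 in one place, on an amine nitrogen whose other neighbour is a saturated chain carbon: a group of 12 heavy atoms (7 carbon, 2 nitrogen, 3 oxygen; one six-membered aromatic ring of carbon only) in place of a group of 11 heavy atoms (8 carbon, 1 nitrogen, 1 oxygen, 1 sulfur; one six-membered aromatic ring of carbon only), on an amine nitrogen. The group that enters is (3-nitrophenyl)carbamoyl. Going by the values given here, no measured pair of compounds differs in only one place, so the expectation rests on the values alone. A small move toward a lower number is expected, probably not beyond the scatter, with compound 1 at 3600 nM as the only reference that also carries a carbonyl on this chain. The estimate implies an expected step of a 1.4-fold lower number from compound 3 to compound 4 (0.14 log units; within the scatter). For compound 4 the estimated value is 6000 nM, with an expected range of 2000 nM to 20000 nM.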

Compound 4, half-maximal inhibitory concentration: 9100 nM
Estimate against measurement, compound 4: 1.5-fold (0.18 log units) below; low and high end bracket the measured number.
By their numbers in this assay, from the lowest: compound 1; then compounds 3 and 4 (each within the scatter of the next). At a limit, above all of these: compound 2.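

In this assay, placing (3-nitrophenyl)carbamoyl on the amine nitrogen gives a 1.1-fold higher number from compound 3 to compound 4 (0.04 log units; within the scatter), and this is the only pair shown that differs in one place. At this position, the sulfur-bearing group and the group that enters, with its nitro-substituted aromatic ring, are thus not told apart by this read-out. Compound 2 alone stands at a limit, which is not a number: the limit of > 50000 nM in this assay, at which 1 of the 4 values shown sits.

The compounds shown leave open whether an amine or a carboxylic acid on the aromatic ring of this group, or a longer chain carrying this amine nitrogen, would move the number beyond the scatter. They also leave open whether the gap to compound 1 has anything to do with this position, since compound 1 differs from compound 3 and compound 4 in more than one place.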